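Aryl swap on the amine nitrogen: cytotoxicity outlook

The compounds below may be only part of what the source reports. "The series", "measured", "known", "first", "only" and "open" are said of these compounds alone.

Compound 1 `Cc1ccc(S(=O)(=O)/N=C(/CCNC2=CC(=O)c3ccccc3C2=O)Nc2ccc(Cl)cc2)cc1` and compound 2 `Cc1ccc(S(=O)(=O)/N=C(/CCNC2=CC(=O)c3ccccc3C2=O)Nc2cccc(C(F)(F)F)c2)cc1` share one core and differ only in the aryl group on the amine nitrogen. In an ADME assay on HEK293 cells (Homo sapiens) for cytotoxicity, read by MTT assay, with a stated time of 48 h (a lower number here means a stronger inhibitor, a higher number a weaker inhibitor), compound 1 gives 65400 nM, and compound 2 gives 91500 nM. Compound 2 holds the larger of the two numbers, but the step of a 1.4-fold higher number from compound 1 to compound 2 (0.15 log units; within the scatter) stays within the scatter, so the pair is not separated. Compound 3 `COc1ccc(N/C(CCNC2=CC(=O)c3ccccc3C2=O)=N\S(=O)(=O)c2ccc(C)cc2)cc1OC` carries 3,4-dimethoxyphenyl in place of 3-(trifluoromethyl)phenyl on an amine nitrogen. Among the measured compounds shown here, the only measured step bearing on this is that same aryl exchange, which left the number within the scatter. For compound 3 no step beyond the scatter is expected, a 1.1-fold lower number from compound 2 to compound 3 (0.06 log units; within the scatter). Compound 3 is estimated at 80000 nM, range 35000 nM to 180000 nM.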

Compound 3, half-maximal inhibitory concentration: 60600 nM
The estimate for compound 3 lay 1.3-fold (0.12 log units) above the measured number, within the range that was stated.
By their numbers in this assay, from the lowest: compounds 3, 1 and 2 (each within the scatter of the next).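

In this assay, 3,4-dimethoxyphenyl on the amine nitrogen gives a 1.5-fold lower number from compound 2 to compound 3 (0.18 log units; within the scatter) and also a 1.1-fold lower number from compound 1 to compound 3 (0.03 log units; within the scatter), so none of the three aryl groups is separated from another. The position thus accepts 3,4-dimethoxyphenyl, with 2 hydrogen-bond acceptors where 3-(trifluoromethyl)phenyl has 0, without a step beyond the scatter. No measurement offers an explanation for these numbers. Still open, from the compounds shown here alone, is whether a carboxylic acid or an amine on the aryl ring, or an alkyl chain in place of it, would give a step beyond the scatter.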